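The compounds below may be only part of what the source reports. "The series", "measured", "known", "first", "only" and "open" are said of these compounds alone.

Compound 1 `COc1cc(/C=C/c2nc(NC3CC3)c3sccc3n2)cc(OC)c1OC`: 6030 nM
Compound 2 `COc1cc(/C=C/c2nc(Nc3ccc(O)cc3)c3sccc3n2)cc(OC)c1OC`: 4070 nM
Compound 3 `COc1ccc(CNc2nc(/C=C/c3cc(OC)c(OC)c(OC)c3)nc3ccsc23)cc1`: 7540 nM

These three numbers come from a functional assay on RAW264.7 cells (Mus musculus) for inhibition, read by Griess assay, with stated times of 1 h and 24 h; a lower number here means a stronger inhibitor, a higher number a weaker inhibitor. Compound 3 sits at the upper end of the three, yet a 1.3-fold higher number from compound 1 to compound 3 (0.10 log units; within the scatter) and a 1.9-fold higher number from compound 2 to compound 3 (0.27 log units; within the scatter) are both within the scatter, so the three compounds are not separated. Compound 4 `COc1cc(/C=C/c2nc(NCc3ccncc3)c3sccc3n2)cc(OC)c1OC` differs from compound 3 by pyridin-4-yl in place of 4-methoxyphenyl on a saturated chain carbon bound to a nitrogen on an aromatic ring. Among the measured compounds shown here, no measured step touches that place: the steps from compound 1 and compound 2 to compound 3 swap the whole group on the nitrogen, and each stayed within the scatter. On this basis compound 4 is expected to give 6500 nM in this assay, between 2500 nM and 16000 nM. The estimated step of a 1.2-fold lower number from compound 3 to compound 4 (0.06 log units; within the scatter) is not expected to exceed the scatter.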

Compound 4, half-maximal inhibitory concentration: 6350 nM
For compound 4 the middle estimate is 1.0-fold (0.01 log units) above the measured one; the range from low to high includes it.
By their numbers in this assay, from the lowest: compounds 2, 1, 4 and 3 (each within the scatter of the next).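

In this assay, among the compounds shown here, pyridin-4-yl in place of 4-methoxyphenyl on a saturated chain carbon bound to a nitrogen on an aromatic ring gives the only step confined to this place (a 1.2-fold lower number from compound 3 to compound 4 (0.07 log units; within the scatter)). Swapping the whole group on the nitrogen for (pyridin-4-yl)methyl also stays within the scatter (a 1.6-fold higher number from compound 2 to compound 4 (0.19 log units; within the scatter); a 1.1-fold higher number from compound 1 to compound 4 (0.02 log units; within the scatter)), so compound 4 is not separated from the other three. No available evidence explains this result.

The compounds shown leave open whether a carboxylic acid or an amine on this ring would give a step beyond the scatter. From the compounds shown here alone, a longer chain between the nitrogen and the ring also remains open.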